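Chlorophenyl isomer step on the sulfonyl sulfur

A few compounds are considered here, and "the series" means these few. Any claim that something is new, unique, unknown or untested is made for them only; others in the source may bear on it.

- compound 1 `CCn1cc(C(=O)O)c(=O)c2cc(F)c(N3CCN(C(=N)NS(=O)(=O)c4ccccc4Cl)CC3)cc21`: 43 nM
- compound 2 `N=C(NS(=O)(=O)c1ccccc1Cl)N1CCN(c2cc3c(cc2F)c(=O)c(C(=O)O)cn3C2CC2)CC1`: 43 nM

In a functional assay on HL-60 cells (Homo sapiens) for antiproliferative activity, read by MTT assay, with a stated time of 72 h (a higher number here means a weaker inhibitor, a lower number a stronger inhibitor), compound 2 gives 43 nM, level with compound 1 at 43 nM. Compound 3 `N=C(NS(=O)(=O)c1ccc(Cl)cc1)N1CCN(c2cc3c(cc2F)c(=O)c(C(=O)O)cn3C2CC2)CC1` differs from compound 2 in one place: 4-chlorophenyl in place of 2-chlorophenyl on a sulfonyl sulfur. It carries 4-chlorophenyl in place of 2-chlorophenyl on a sulfonyl sulfur.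

Among the measured compounds shown here, the only measured step, no change at the digits printed from compound 1 to compound 2 (within the scatter), is cyclopropyl in place of ethyl on an aromatic nitrogen. It leaves the group on the sulfonyl sulfur untouched, so it bears on the new change only indirectly. For the measured compounds named here, no measured compound varies that group, and the data give no direction. The step expected in this assay is estimated as a 1.4-fold higher number from compound 2 to compound 3 (0.14 log units; within the scatter), which is none beyond the scatter, though with wide uncertainty. For compound 3 the estimated value is 60 nM, with an expected range of 15 nM to 240 nM.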

Compound 3, half-maximal inhibitory concentration: 43 nM
Compound 3: middle estimate off by 1.4-fold (0.14 log units), on the high side; the range from low to high includes it.
By their numbers in this assay, from the lowest: compounds 1, 2 and 3 (each within the scatter of the next).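

In this assay, 4-chlorophenyl in place of 2-chlorophenyl on a sulfonyl sulfur gives no change at the digits printed from compound 2 to compound 3 (within the scatter). This is the only change among the compounds shown that touches the aryl group on the sulfonyl sulfur, and it shows that this read-out does not separate these two chlorophenyl isomers, whereas the earlier step concerned only the group on the aromatic nitrogen. No measurement shown bears on the reason for this flat result.

Going by these compounds, whether an unsubstituted phenyl, a methoxyphenyl or a plain methyl on the sulfonyl sulfur would stay at the same level remains open. Also open, on these data alone, is whether 4-chlorophenyl would read the same alongside the ethyl group of compound 1 on the aromatic nitrogen.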